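Shortening the ether chain: outlook for compound 3

The source may report more compounds than this note shows. Statements on the series, on what has been measured and on what is new or still open speak of the compounds shown alone.

Measured so far in a functional assay on MCF7 cells (Homo sapiens), tested at 7.5 uM; a lower number here means a stronger effect, a higher number a weaker effect of the compound at the concentration tested:
compound 1 `Cc1c(C)c2c(c(C)c1OC(=O)CCC(=O)O)CCC(C)(COc1ccc(/C=C3\SC(=O)NC3=O)cc1)O2`, 76%
compound 2 `Cc1c(C)c2c(c(C)c1OC/C=C/c1ccccc1)CCC(C)(COc1ccc(/C=C3\SC(=O)NC3=O)cc1)O2`, 43%

For the measured compounds named here, compound 2 gives the lower of the two numbers in this assay; its nearest neighbour is compound 1, and the one step measured, a number 33 percentage points lower from compound 1 to compound 2 (beyond the scatter), lies beyond the scatter and is large. That step exchanges an ester-type group for an allylic ether on the ring oxygen, so it tells nothing directly about trimming that ether once it is in place.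

Compound 3 `Cc1c(C)c2c(c(C)c1OCc1ccccc1)CCC(C)(COc1ccc(/C=C3\SC(=O)NC3=O)cc1)O2` is the next member. It differs from compound 2 by phenyl in place of 2-phenylethenyl on a saturated chain carbon bound to an oxygen on an aromatic ring. Going by the values given here, no measured pair shows a change of this kind; the ether linkage to the aromatic oxygen and the rest of the shared core of compound 2 are kept, only the double bond and its two chain carbons are removed. Among the compounds with values here, with no step of this sort to draw on, the step of a number 7 percentage points higher from compound 2 to compound 3 (within the scatter) is expected to stay within the scatter, in either direction. Compound 3 is therefore estimated at 50%, within the range 30% to 75%.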

Compound 3, a percentage reported as activity, at one concentration (the size of the read-out at that concentration, not a potency): 12%
The estimate for compound 3 lay 38 percentage points above the measured number; the whole stated range lies above it.
By their numbers in this assay, from the lowest: compound 3; then compound 2; then compound 1.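

In this assay, the group beyond the ring oxygen still matters once the ether linkage is in place: replacing 3-phenylprop-2-en-1-yl with benzyl gives a number 31 percentage points lower from compound 2 to compound 3 (beyond the scatter), a change the earlier exchange of an ester-type group for an ether could not reveal. Compared directly with the (2-carboxyethyl)carbonyl group, benzyl gives the widest step in the set, a number 64 percentage points lower from compound 1 to compound 3 (beyond the scatter), so within these three compounds the removal of the double bond and its two chain carbons extends the fall already seen on moving to the ether rather than cancelling it. No evidence is available to account for the step between the two ethers.

These compounds do not separate the loss of the double bond from the shortening of the chain, and a saturated 3-phenylpropyl ether would tell the two apart. On these data alone, it also remains open whether the aromatic ring of the benzyl group is needed at all, which a plain methyl ether would address, and whether that ring tolerates an added group such as an amine or a carboxylic acid.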